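A triazole series moves from sulfonamide to methoxyphenyl

The compounds below may be only part of what the source reports. "The series", "measured", "known", "first", "only" and "open" are said of these compounds alone.

Of the compounds shown here, two have been tested in a functional assay on HepG2 cells (Homo sapiens) for antiproliferative activity, read by MTT assay, with a stated time of 72 h; a lower number here means a stronger inhibitor, a higher number a weaker inhibitor. Compound 1 `Cc1ccc(-c2cn(C/C=C3\OC(=O)C(OCc4ccccc4)=C3OCc3ccccc3)nn2)cc1` gives only a limit there, > 100000 nM, so no number is known for it. Within the data shown here, compound 2 `O=C1O[C@H]([C@@H](O)Cn2cc(CNS(=O)(=O)c3ccc(F)cc3)nn2)C(OCc2ccccc2)=C1OCc1ccccc1` gives 18300 nM in this assay, the only number in the set. A ranking of compound 2 against compound 1 is not possible; compound 1 has no number. Compound 3 `COc1ccc(-c2cn(C[C@H](O)[C@H]3OC(=O)C(OCc4ccccc4)=C3OCc3ccccc3)nn2)cc1` has not yet been measured. It differs from compound 2 in one place: 4-methoxyphenyl in place of (((4-fluorophenyl)sulfonyl)amino)methyl on an aromatic carbon. Among the measured compounds shown here, no step between measured compounds that changes only this group is available, so the size of the change can only be guessed. Compound 3 is expected to be a weaker inhibitor than compound 2, with an expected step of a 2.2-fold higher number from compound 2 to compound 3 (0.34 log units; beyond the scatter) in this assay. The estimate for compound 3 in this assay is 40000 nM, in a range from 10000 nM to 150000 nM.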

Compound 3, half-maximal inhibitory concentration: 46400 nM
Estimate against measurement, compound 3: 1.2-fold (0.06 log units) below, within the range that was stated.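

Among these compounds, this is the first step that can be read at this position, an aromatic carbon of the five-membered aromatic ring with 3 nitrogen: in this assay, 4-methoxyphenyl in place of (((4-fluorophenyl)sulfonyl)amino)methyl gives a 2.5-fold higher number from compound 2 to compound 3 (0.40 log units; beyond the scatter). The step is modest, and in this pair a group with no hydrogen-bond donor still gives a value that can be read, so the sulfonyl and amino atoms are not needed for a measurable number. Compound 1 remains a limit and not a number, so no step to it can be read: the limit of > 100000 nM in this assay, at which 1 of the 3 values shown sits.

A single step that swaps two such different groups cannot separate the part played by the sulfonyl and amino atoms from that of the methoxy group. The compounds shown also do not tell how a simple amine or a carboxylic acid at this position would read in this assay.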